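A few compounds are considered here, and "the series" means these few. Any claim that something is new, unique, unknown or untested is made for them only; others in the source may bear on it.

Measured compounds:
compound 1, `COc1cc2c(cc1OC)CN(S(=O)(=O)c1ccc(-n3cc(COc4ccccc4C(C)=O)nn3)cc1)CC2` — > 50 ug/mL
compound 2, `O=Cc1ccc(OCc2cn(-c3ccc(S(=O)(=O)N4CCc5ccccc5C4)cc3)nn2)cc1` — > 50 ug/mL
compound 3, `O=S(=O)(c1ccc(-n2cc(COc3ccccc3)nn2)cc1)N1CCc2ccccc2C1` — > 50 ug/mL

In a functional assay on HuCC-A1 cells (Homo sapiens) for cytotoxicity, read by MTT assay, with a stated time of 48 h (on this read-out higher numbers stand for weaker inhibition and lower numbers for stronger inhibition), compound 1 gives only a limit, > 50 ug/mL, not a number. Compound 2 likewise gives only a limit in this assay. The same holds for compound 3. For the measured compounds named here, the one measured step, a step that the two limits leave unreadable from compound 2 to compound 3, is therefore unreadable, since both ends are limits.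

Compound 4, `COc1cc2c(cc1OC)CN(S(=O)(=O)c1ccc(-n3cc(COc4ccc(C)cc4)nn3)cc1)CC2`, differs from compound 1 in one place: 4-methylphenyl in place of 2-acetylphenyl on an oxygen on a saturated carbon. Going by the values given here, no measured step covers this kind of exchange, and the only evidence on the numbers is the limit of > 50 ug/mL in this assay, at which 3 of the 3 values shown sit, which sets no direction for any change.

What can be expected for compound 4 rests only on where compound 1 stands, at the limit. Compound 4 is estimated to give 70 ug/mL in this assay, with a likely spread from 30 ug/mL to 200 ug/mL. The expected step that the limit leaves unreadable from compound 1 to compound 4 is thus no change that could be read beyond the scatter, and a further limit rather than a number is the most likely outcome.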

Compound 4, half-maximal inhibitory concentration: > 50 ug/mL
Compound 4: no number, only a limit; the forecaster's own chance of this, stated with the estimate: 80%; the middle value lies beyond the limit too.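

In this assay compound 4 gives > 50 ug/mL, which is a limit and not a number. For the compounds shown here, compound 1 also gives only a limit, so no step between compound 1 and compound 4 can be read. The compounds shown leave open how far any of these exchanges shifts cytotoxicity, and all of them rest at one limit: the limit of > 50 ug/mL in this assay, at which 4 of the 4 values shown sit.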